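Growth inhibition series: methoxy added to compound 2

The source may report more compounds than this note shows. Statements on the series, on what has been measured and on what is new or still open speak of the compounds shown alone.

Measured so far in a functional assay on MCF7 cells (Homo sapiens) for cytotoxicity, read by MTT assay, with a stated time of 72 h; a higher number here means a weaker inhibitor of growth, a lower number a stronger inhibitor of growth:
compound 1 `CCCOC(=O)Nc1ccc([Se]C#N)cc1`: 8000 nM
compound 2 `N#C[Se]c1ccc(NC(=O)Oc2ccccc2)cc1`: 4000 nM
compound 3 `CCCCOC(=O)Nc1ccc([Se]C#N)cc1`: 6600 nM

Compound 2 gives the smallest number of the three, yet a 2.0-fold lower number from compound 1 to compound 2 (0.30 log units; within the scatter) and a 1.7-fold higher number from compound 2 to compound 3 (0.22 log units; within the scatter) both stay within the scatter, so the three compounds cannot be told apart on these numbers. The same holds for a 1.2-fold lower number from compound 1 to compound 3 (0.08 log units; within the scatter).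

Compound 4 `COc1ccc(OC(=O)Nc2ccc([Se]C#N)cc2)cc1` is the next compound, not yet measured. Relative to compound 2 the change is methoxy in place of hydrogen on an aromatic carbon. Within the data shown here, no measured step alters an aromatic ring of the series; the three known steps all exchange or extend the group on the oxygen next to the carbonyl group, and none of them moved the number beyond the scatter. There is therefore no measured basis for a shift in either direction, and the expectation is a step from compound 2 to compound 4 of no change at the digits printed from compound 2 to compound 4 (within the scatter), no larger than the scatter. Compound 4 is thus estimated at 4000 nM in this assay, within a range of 1500 nM to 10000 nM.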

Compound 4, concentration for 50% growth inhibition: 22400 nM
Beside the measured number, compound 4's estimate is 5.6-fold (0.75 log units) below it; measured number above the stated range.
By their numbers in this assay, from the lowest: compounds 2, 3 and 1 (each within the scatter of the next); then compound 4.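

Working notes on the series: in this assay, methoxy in place of hydrogen on an aromatic carbon, para to a large group, gives a 5.6-fold higher number from compound 2 to compound 4 (0.75 log units; beyond the scatter) and is the only step shown that lies beyond the scatter. The terminal ring of compound 2 is therefore a place where a substitution moves the number upward, whereas exchanging propyl, butyl and phenyl on the oxygen next to the carbonyl group gave no step beyond the scatter. No supporting data bear on why methoxy has this effect here.

Going by these compounds, whether the rise belongs to methoxy itself or to any group at this carbon remains open, and fluorine, methyl or hydroxyl at the same place would separate the two. On these data alone, the effect of methoxy at the other carbons of this ring also remains open.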